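A few compounds are considered here, and "the series" means these few. Any claim that something is new, unique, unknown or untested is made for them only; others in the source may bear on it.

Three ureas built on one shared core have been tested in a functional assay on SNB-75 cells (Homo sapiens) for inhibition, read by sulforhodamine B assay, with a stated time of 48 h, tested at 10 uM; a higher number here means a weaker effect of the compound at the concentration tested, a lower number a stronger effect. Compound 1, `COc1cc2cc(Oc3ccc(NC(=O)Nc4ccccc4)cc3)c(C)nc2cc1OC`, gives 75.8% in this assay. Compound 2, `COc1cc2cc(Oc3ccc(NC(=O)Nc4ccc(C(F)(F)F)cc4)cc3)c(C)nc2cc1OC`, gives 41% in this assay, a change of a number 34.8 percentage points lower from compound 1 to compound 2 (beyond the scatter). Compound 3, `COc1cc2cc(Oc3ccc(NC(=O)Nc4ccc(Cl)c(C(F)(F)F)c4)cc3)c(C)nc2cc1OC`, gives 12.5% in this assay, the lowest of the three numbers, with a change of a number 28.5 percentage points lower from compound 2 to compound 3 (beyond the scatter) and of a number 63.3 percentage points lower from compound 1 to compound 3 (beyond the scatter). Compound 3 therefore stands furthest from compound 1 and nearer to compound 2, both gaps beyond the scatter.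

Compound 4, `COc1cc2cc(Oc3ccc(NC(=O)Nc4ccc(Cl)c(Cl)c4)cc3)c(C)nc2cc1OC`, differs from compound 3 in one place: chloro in place of trifluoromethyl on an aromatic carbon. Among the compounds with values here, no measured step tests chloro against trifluoromethyl directly. Within the data shown here, the steps that bear on it are the gain from adding trifluoromethyl, a number 34.8 percentage points lower from compound 1 to compound 2 (beyond the scatter), and the further gain from the chloro-bearing ring, a number 28.5 percentage points lower from compound 2 to compound 3 (beyond the scatter), both of which moved the number down. A single halogen in place of trifluoromethyl on a ring that already carries chloro is expected to cost only a little of that gain, so the estimated step is a number 7.5 percentage points higher from compound 3 to compound 4 (within the scatter), probably within the scatter. Compound 4 is thus expected to give about 20% in this assay, between 8% and 38%.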

Compound 4, a percentage reported as activity, at one concentration (the size of the read-out at that concentration, not a potency): 22.4%
Compound 4: middle estimate off by 2.4 percentage points, on the low side; low and high end bracket the measured number.
By their numbers in this assay, from the lowest: compounds 3 and 4 (each within the scatter of the next); then compound 2; then compound 1.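

In this assay, chloro in place of trifluoromethyl on the aromatic carbon ortho to a chloro group gives a number 9.9 percentage points higher from compound 3 to compound 4 (within the scatter), so at this position the group of one heavy atom and the group of four heavy atoms cannot be told apart in this assay. The 3,4-dichlorophenyl urea also stays clearly separated from the two ureas without a group at this position, with a number 18.6 percentage points lower from compound 2 to compound 4 (beyond the scatter) and a number 53.4 percentage points lower from compound 1 to compound 4 (beyond the scatter), which shows that among these compounds trifluoromethyl is not required there for the stronger effect seen with compound 3. Nothing available on these compounds explains why the two groups read alike here.

The compounds shown leave open whether other groups at this position, such as methoxy, a nitrile, an amine or a carboxylic acid, would keep the effect, and whether the plain 4-chlorophenyl urea, with hydrogen at this position, would already match compound 3 and compound 4. They also leave open whether this likeness would hold at other concentrations or in other cells, since the read-out here is the size of the effect at one concentration and not a potency.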